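This account rests on a few compounds, and the source may have more. Where it says the series, first, only, none or still open, it means among the compounds named here.

Within an assay on COS-7 cells for inhibition of diacylglycerol lipase-alpha (Homo sapiens), read by scintillation counting (on this read-out higher numbers stand for weaker inhibition and lower numbers for stronger inhibition), compound 3, `CCCCCCCCCCC[C@@H](C[C@@H]1OC(=O)[C@H]1CCCCCC)OC(=O)[C@H](C)NC=O`, stands as the only value given as a number: in this assay compound 3 gives 43 nM. Compound 1, `CCCCCCCCCCC[C@@H](C[C@@H]1OC(=O)[C@H]1CCCCCC)OC(=O)CCC(C)C`, reaches only the limit of the assay, giving > 25000 nM. Compound 2, `CCCCCCCCCCC[C@@H](C[C@@H]1OC(=O)[C@H]1CCCCCC)OC(=O)CNC(=O)OCc1ccccc1`, likewise reaches only the limit, giving > 25000 nM. Both limits sit at the limit of > 25000 nM in this assay, at which 2 of the 3 values shown sit, so the step that the two limits leave unreadable from compound 1 to compound 2 cannot be read. The two steps that do carry a size both end at compound 3: an at least 580-fold lower number from compound 1 to compound 3 (2.76 log units; beyond the scatter) and an at least 580-fold lower number from compound 2 to compound 3 (2.76 log units; beyond the scatter). In each case the formylamino-bearing group on the carbonyl carbon goes with the large drop.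

Compound 4, `CCCCCCCCCCC[C@@H](C[C@@H]1OC(=O)[C@H]1CCCCCC)OC(=O)CCNC=O`, has not yet been measured. It differs from compound 3 as follows: a group of 5 heavy atoms (3 carbon, 1 nitrogen, 1 oxygen; no ring) in place of a group of 5 heavy atoms (3 carbon, 1 nitrogen, 1 oxygen; no ring), on a carbonyl carbon. The two compounds hold the same atoms, joined differently: the defined stereocentre of compound 3 is lost, and the 2-(formylamino)ethyl group of compound 4 carries its formylamino one carbon further from the carbonyl. Among the compounds with values here, no measured step covers this rearrangement; the measured steps show only that the presence of the formylamino group, not its position, separates compound 3 from compound 1 and compound 2.

Compound 4 is therefore expected to stay well clear of the limit but somewhat weaker than compound 3, an expected step of a 5.8-fold higher number from compound 3 to compound 4 (0.76 log units; beyond the scatter). The estimate for compound 4 is 250 nM, with a range from 40 nM to 2500 nM.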

Compound 4, half-maximal inhibitory concentration: 600 nM
For compound 4 the middle estimate is 2.4-fold (0.38 log units) below the measured one; the range from low to high includes it.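

In this assay, the placement of the formylamino group matters as well as its presence: exchanging the group of compound 3 for the 2-(formylamino)ethyl group, with the same atoms joined differently, gives a 14-fold higher number from compound 3 to compound 4 (1.14 log units; beyond the scatter). The 2-(formylamino)ethyl group still retains much of the gain, with an at least 41-fold lower number from compound 2 to compound 4 (1.61 log units; beyond the scatter) and an at least 41-fold lower number from compound 1 to compound 4 (1.61 log units; beyond the scatter), so in these four compounds the two formylamino-bearing groups go with lower numbers than the isobutyl and (benzyloxycarbonyl)aminomethyl groups. The sizes of these last two steps are bounds only, because compound 1 and compound 2 each give a limit rather than a number: the limit of > 25000 nM in this assay, at which 2 of the 4 values shown sit.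

The step to compound 4 removes the defined stereocentre and moves the formylamino group in a single change, so the compounds shown cannot separate the share of each, and the opposite configuration at that stereocentre is not covered. As far as these compounds go, it also remains open whether the formyl group itself is needed, which an acetylamino group or a free amine on the same carbon would address, and whether a longer chain such as 3-(formylamino)propyl would continue the trend seen with compound 4.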